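The source may report more compounds than this note shows. Statements on the series, on what has been measured and on what is new or still open speak of the compounds shown alone.

Compound 1 `COc1ccc(-c2nc(N)n(-c3ncnc4ccccc34)n2)cc1` gives 5000 nM in a physicochemical assay for solubility, in phosphate buffer, with a stated time of 18 h, at pH 7.4; on this read-out lower numbers stand for lower solubility and higher numbers for higher solubility. Compound 2 `Nc1cc2c(-n3nc(-c4ccccn4)nc3N)ncnc2cc1Cl` gives 3000 nM in this assay, and compound 3 `COc1cc2ncnc(-n3nc(-c4ccccn4)nc3N)c2cc1N` gives 3000 nM. Compound 3 therefore stands level with compound 2, the two together the lowest of the three numbers, while its gap to compound 1 lies within the scatter. Compound 4 `COc1cc2ncnc(-n3nc(-c4ccccn4)nc3N)c2cc1OCCCNC(=O)OC(C)C` differs from compound 3 in one place: 3-((isopropoxycarbonyl)amino)propoxy in place of amino on an aromatic carbon. For the measured compounds named here, the only measured step, no change at the digits printed from compound 2 to compound 3 (within the scatter), concerns a different group and does not bear on this change, so no measured step speaks to it. The expected step of a 1.2-fold lower number from compound 3 to compound 4 (0.08 log units; within the scatter) reflects that nothing measured argues for a change beyond the scatter. Compound 4 is therefore estimated at 2500 nM, with a range from 800 nM to 8000 nM.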

Compound 4, solubility: 18000 nM
Beside the measured number, compound 4's estimate is 7.2-fold (0.86 log units) below it; the whole stated range lies below it.
By their numbers in this assay, from the lowest: compounds 2, 3 and 1 (each within the scatter of the next); then compound 4.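

For the compounds shown here, on this aromatic carbon, ortho to a methoxy group, this assay responds to the group placed there: 3-((isopropoxycarbonyl)amino)propoxy in place of amino gives a 6.0-fold higher number from compound 3 to compound 4 (0.78 log units; beyond the scatter) and is the first step to go beyond the scatter. The position therefore carries a chain of 11 heavy atoms where amino has 1, and the number rises rather than falls. Nothing measured here explains this rise.

It remains open which part of the chain matters, since only this one chain is shown. A plain propoxy, a chain ending in a free amine or a carboxylic acid, or a longer chain could separate the linker from its end group.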